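Amide nitrogen variation on the shared sulfonamide core

The source may report more compounds than this note shows. Statements on the series, on what has been measured and on what is new or still open speak of the compounds shown alone.

Measured compounds:
compound 1 `COc1ccc(Cl)cc1N(CC(=O)Nc1cccc2ccccc12)S(=O)(=O)c1ccccc1`; in a functional assay on SH-SY5Y cells (Homo sapiens), read by MTT assay, with a stated time of 24 h (a higher number here means that more compound is needed for the effect, a lower number that less compound is needed), compound 1 gives 17400 nM
compound 2 `CCCNC(=O)CN(c1cc(Cl)ccc1OC)S(=O)(=O)c1ccccc1`; in this assay compound 2 gives > 20000 nM, which is a limit of the assay and not a number

Compound 2 thus stands at the limit, described by the limit of > 20000 nM in this assay, at which 1 of the 2 values shown sits, and its true position relative to compound 1 is open. Among the measured compounds shown here, the only measured step, an at least 1.1-fold higher number from compound 1 to compound 2 (0.06 log units; that floor lies within the scatter), moved the value from a number to this limit.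

Compound 3 `CCN(CC)C(=O)CN(c1cc(Cl)ccc1OC)S(=O)(=O)c1ccccc1` is the next step: diethylamino in place of propylamino on a carbonyl carbon. For the measured compounds named here, no measured step covers this kind of change on the carbonyl carbon, since the step from compound 1 to compound 2 exchanged a naphthalen-1-yl for a propyl on the amide-type nitrogen rather than adding a second alkyl. The step to compound 3 is therefore expected to be a step that the limit leaves unreadable from compound 2 to compound 3, with compound 2 as the only anchor and that anchor itself a limit.

For compound 3 in this assay the estimate is 30000 nM, range 8000 nM to 100000 nM, most likely again reported as a limit.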

Compound 3, half-maximal effective concentration: > 20000 nM
Compound 3 ended at the assay's limit; the forecaster's own chance of this, stated with the estimate: 80%; the middle value does not contradict the limit.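

In this assay compound 3 gives > 20000 nM, which is a limit of the assay and not a number. Diethylamino in place of (naphthalen-1-yl)amino gives an at least 1.1-fold higher number from compound 1 to compound 3 (0.06 log units; that floor lies within the scatter), so this second replacement on the carbonyl carbon again yields only a floor, and the true size of the step remains unknown. With 0 hydrogen-bond donors in diethylamino against 1 in propylamino, the change still gives no readable result, and the step from compound 2 to compound 3 cannot be read because both ends are limits: the limit of > 20000 nM in this assay, at which 2 of the 3 values shown sit.

Open, going by these compounds, is how far compound 2 and compound 3 lie from compound 1. Also open, on these data alone, is whether a value that is a number on this core goes with a ring on the amide nitrogen, as a benzylamino or phenylamino group on the carbonyl carbon could show.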